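Phenyl for Methyl on a Fused Core, Second Instance

The source may report more compounds than this note shows. Statements on the series, on what has been measured and on what is new or still open speak of the compounds shown alone.

Three compounds have been measured in a functional assay for inhibition, with Homo sapiens as the target; a higher number here means a weaker inhibitor, a lower number a stronger inhibitor:
- compound 1 `C=CCSc1nncc2cnc(C)n12`: 61000 nM
- compound 2 `C=CCSc1nncc2cnc(-c3ccccc3)n12`: a limit of the assay, > 48000 nM
- compound 3 `C=CCSc1nncc2c(C)nc(C)n12`: 59000 nM

Compound 4 `C=CCSc1nncc2c(C)nc(-c3ccccc3)n12` has not yet been measured. Compound 1 and compound 3 differ in their cores by methyl in place of hydrogen on an aromatic carbon, and this gives a 1.0-fold lower number from compound 1 to compound 3 (0.01 log units; within the scatter). The change from compound 1 to compound 2 is phenyl in place of methyl on an aromatic carbon, and its step is a step that the limit leaves unreadable from compound 1 to compound 2, since compound 2 sits at the limit of > 48000 nM in this assay, at which 1 of the 3 values shown sits. The change from compound 3 to compound 4 is the same kind of change, (phenyl in place of methyl on an aromatic carbon), though here the place is also two ring bonds from the ring atom that bears a methyl group. Because the earlier instance ended at the limit of > 48000 nM in this assay, at which 1 of the 3 values shown sits, the step of a 1.3-fold higher number from compound 3 to compound 4 (0.10 log units; within the scatter) is expected to be of similar unreadable size or larger. Compound 4 is therefore estimated at 75000 nM, with a range from 40000 nM to 160000 nM, and quite possibly only a limit will be reported.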

Compound 4, half-maximal inhibitory concentration: > 48000 nM
Compound 4: no number, only a limit; the forecaster's own chance of this, stated with the estimate: 60%; the middle value is on the limit's open side.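

Compound 4 gives > 48000 nM, a limit of the assay and not a number, so its steps from compound 3 and compound 2 cannot be read. The compounds shown leave open how large the change from methyl to phenyl is on either core.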